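The source may report more compounds than this note shows. Statements on the series, on what has been measured and on what is new or still open speak of the compounds shown alone.

Working notes on the series.

Three compounds carry the shared core, and one more is to be measured. Compound 1 `CN(C[C@H]1Cc2c(cccc2N2CCN(C3CC3)CC2)CN1)[C@H]1CCCc2cccnc21` gives 15.5% in an ADME assay on microsomes from liver (Homo sapiens) for metabolic stability, read by LC-MS, with a stated time of 10 min; a higher number here means that more of the compound is left, a lower number that less of the compound is left. Compound 3 `Cc1cnc2c(c1)CCC[C@@H]2N(C)C[C@H]1Cc2c(cccc2N2CCNCC2)CN1` gives 47.8% in this assay. For compound 2 `Cc1cnc(CN(C)C[C@H]2Cc3c(cccc3N3CCNCC3)CN2)c(C)c1` the result in this assay reads "not determined" (no result reported), so no number is available for it.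

Among the two numbers known, compound 1 stands lowest; compound 3 lies higher by a gap beyond the usual scatter. Among the compounds with values here, no two measured compounds differ in one place only, so no single change in this set has a measured step attached to it.

Compound 4 `CCN1CCN(c2cccc3c2C[C@H](CN(C)[C@H]2CCCc4cccnc42)NC3)CC1` is the next entry. Set against compound 1 it differs in one place: ethyl in place of cyclopropyl on an amine nitrogen in a ring the change leaves a three-membered non-aromatic ring of carbon only and brings in a chain with no ring, with no change in hydrogen-bond donors, acceptors or net charge.

With no measured step of this kind in hand, the expectation for the change from compound 1 to compound 4 in this assay is a small move, if any, most likely within the scatter or a modest rise, as expressed by a number 6.5 percentage points higher from compound 1 to compound 4 (within the scatter). For compound 4 the estimated value in this assay is 22%, with a range from 8% to 40%.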

Compound 4, percent of the compound remaining: 0%
For compound 4 the middle estimate is 22 percentage points above the measured one, outside the stated range (below it).
By their numbers in this assay, from the lowest: compound 4; then compound 1; then compound 3.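

In this assay, within the data shown here, ethyl in place of cyclopropyl on an amine nitrogen in a ring gives the first measured single-place step, read as a number 15.5 percentage points lower from compound 1 to compound 4 (beyond the scatter), so the group at this position is not indifferent for the percentage of compound remaining. With compound 4 at 0%, the read-out has no room left to fall, and the printed step may therefore understate the true difference between 4-cyclopropylpiperazin-1-yl and 4-ethylpiperazin-1-yl. No measurement at hand accounts for the difference between these two groups, so the step stands as an observation without an established cause.

One pair of groups cannot show whether cyclopropyl is unusual at this nitrogen or ethyl is, and a methyl, an isopropyl, a longer chain such as propyl or an unsubstituted amine at the same place on the core of compound 1 would help to separate the two readings. As far as these compounds go, it also remains open whether the exchange of cyclopropyl for ethyl would give a step of similar direction and size with the other parts of the molecule changed.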